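A tert-butyl group replaces methoxy in compound 4

A few compounds are considered here, and "the series" means these few. Any claim that something is new, unique, unknown or untested is made for them only; others in the source may bear on it.

In a functional assay on SK-N-SH cells (Homo sapiens) for cytotoxicity, read by MTT assay, with a stated time of 48 h (a higher number here means a weaker inhibitor, a lower number a stronger inhibitor), compound 1 `COc1ccc(/C=C/c2cc(OC)c(OC)c(OC)c2-c2ccc(OC)cc2)cc1` gives 36000 nM, compound 2 `COc1ccc(/C=C/c2cc(OC)c(OC)c(OC)c2-c2ccccc2)cc1` gives 11000 nM and compound 3 `C=C(c1ccc(OC)cc1)c1cc(OC)c(OC)c(OC)c1-c1ccc(OC)cc1` gives 75000 nM. Compound 3 therefore has the highest number of the three and is the weakest inhibitor among them. Compound 4 `C=C(c1ccc(OC)cc1)c1cc(OC)c(OC)c(OC)c1-c1ccc(C(C)(C)C)cc1` keeps the rest of compound 3 but carries tert-butyl in place of methoxy on an aromatic carbon, para to a large group (tert-butyl in place of methoxy on an aromatic carbon). The nearest evidence is the step that swaps this methoxy for hydrogen, a 3.3-fold lower number from compound 1 to compound 2 (0.51 log units; beyond the scatter), a modest move towards stronger inhibition. The other measured step, a 2.1-fold higher number from compound 1 to compound 3 (0.32 log units; beyond the scatter), changes a different part of the molecule and says little about this swap. Within the data shown here, no measured compound carries tert-butyl, so the first step is only a rough guide. A modest step to a lower number in this assay is therefore expected, though with wide uncertainty. The estimated change is a 1.9-fold lower number from compound 3 to compound 4 (0.27 log units; within the scatter). For compound 4 the expected value is 40000 nM, with an estimated range from 15000 nM to 100000 nM.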

Compound 4, half-maximal inhibitory concentration: 24000 nM
Beside the measured number, compound 4's estimate is 1.7-fold (0.22 log units) above it, within the range that was stated.
By their numbers in this assay, from the lowest: compound 2; then compounds 4 and 1 (each within the scatter of the next); then compound 3.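

In this assay the move from 4-methoxyphenyl to 4-(tert-butyl)phenyl gives a 3.1-fold lower number from compound 3 to compound 4 (0.49 log units; beyond the scatter), so the number here does not depend on keeping methoxy, and a group with more heavy atoms and no hydrogen-bond acceptor is compatible with a lower number. Until now the only change at this place was the loss of methoxy to hydrogen, a 3.3-fold lower number from compound 1 to compound 2 (0.51 log units; beyond the scatter), on the other linking arrangement; the two steps point the same way, so replacing this methoxy lowers the number in both pairs shown, whether the incoming group is small or large. Nothing available explains why either step goes this way.

Still open, on these data alone, is whether hydrogen would give a similar step on the core of compound 3, and whether tert-butyl would do so on the core of compound 1. As far as these compounds go, how an amine or a carboxylic acid would behave at this place also remains unknown.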